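Swapping methyl for methoxy on the sulfonyl-bearing ring

This account rests on a few compounds, and the source may have more. Where it says the series, first, only, none or still open, it means among the compounds named here.

Of the compounds shown here, three sharing one core have been tested in a functional assay on HCT-116 cells (Homo sapiens) for cytotoxicity, read by MTT assay, with a stated time of 72 h; a higher number here means a weaker inhibitor, a lower number a stronger inhibitor. Compound 1, `COc1ccc(Nc2nc3ccccc3nc2S(=O)(=O)c2ccc(C)cc2)cc1`, reaches only a limit of the assay. In this assay compound 1 gives > 50000 nM, a limit rather than a number. Compound 2, `COc1cc(Nc2nc3ccccc3nc2S(=O)(=O)c2ccc(C)cc2)cc(OC)c1`, is the starting point of the present step. In this assay compound 2 gives > 50000 nM, again a limit and not a number. Among the measured compounds shown here, compound 3, `Cc1ccc(S(=O)(=O)c2nc3ccccc3nc2Nc2ccc(F)cc2)cc1`, is the only one with a read number. In this assay compound 3 gives 10500 nM. Compound 1 and compound 2 both sit at the limit of > 50000 nM in this assay, at which 2 of the 3 values shown sit.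

The step from compound 1 to compound 2 is a step that the two limits leave unreadable from compound 1 to compound 2. The step from compound 2 to compound 3 is an at least 4.7-fold lower number from compound 2 to compound 3 (0.67 log units; beyond the scatter), and the step from compound 1 to compound 3 is an at least 4.7-fold lower number from compound 1 to compound 3 (0.67 log units; beyond the scatter). All three concern the group carried on the nitrogen, and none touches the other aromatic ring.

Compound 4, `COc1ccc(S(=O)(=O)c2nc3ccccc3nc2Nc2cc(OC)cc(OC)c2)cc1`, differs from compound 2 by methoxy in place of methyl on an aromatic carbon. For the measured compounds named here, no measured step concerns this position, so the measured steps give no direct guide. The expected step from compound 2 to compound 4 is a number no higher from compound 2 to compound 4 (the limit leaves the size open), with compound 4 most likely staying at the limit. Compound 4 is estimated at 50000 nM, within 20000 nM to 150000 nM.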

Compound 4, half-maximal inhibitory concentration: 13400 nM
Estimate against measurement, compound 4: 3.7-fold (0.57 log units) above; the whole stated range lies above it.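

The earlier steps shown here all changed the group on the nitrogen, so they said nothing about the other aromatic ring. This result shows that the group on that ring, at the place para to a large group, can also move the number in this assay, with an at least 3.7-fold lower number from compound 2 to compound 4 (0.57 log units; beyond the scatter). The change from 4-methylphenyl to 4-methoxyphenyl alone takes compound 4 to a read number while the 3,5-dimethoxyphenyl group on the nitrogen stays as it was, and the true size of the step remains open since compound 2 has no read number: the limit of > 50000 nM in this assay, at which 2 of the 4 values shown sit.

With only methyl and methoxy shown at this carbon, it remains open whether the gain is particular to methoxy or whether an amine, a carboxylic acid or a longer chain such as ethoxy at the same place would give a similar step. Going by these compounds, it is also open whether the same swap would give a step of like size with 4-methoxyphenyl or 4-fluorophenyl on the nitrogen.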